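The source may report more compounds than this note shows. Statements on the series, on what has been measured and on what is new or still open speak of the compounds shown alone.

Three compounds share one core. Compound 1 `CCOCc1c(C)coc1-c1ccc2c(CC)cccc2c1OC` carries an ethoxy group on a saturated chain carbon bound to an aromatic carbon. In a functional assay on KB cells (Homo sapiens) for cytotoxicity, read by MTT assay, with a stated time of 72 h (on this read-out higher numbers stand for an effect only at larger amounts of compound and lower numbers for an effect already at smaller amounts), compound 1 gives > 10 ug/mL, which is a limit of the assay rather than a number. Compound 2 `CCc1cccc2c(OC)c(-c3occ(C)c3CBr)ccc12` has bromo in place of that ethoxy. In this assay compound 2 gives > 10 ug/mL, again only a limit. Among the measured compounds shown here, compound 3 `CCc1cccc2c(OC)c(-c3occ(C)c3COCC(F)(F)F)ccc12` carries 2,2,2-trifluoroethoxy at the same place, and in this assay compound 3 gives 6.6 ug/mL, the only real number among the three, the other two sitting at the limit of > 10 ug/mL in this assay, at which 2 of the 3 values shown sit. The steps of an at least 1.5-fold lower number from compound 1 to compound 3 (0.18 log units; that floor lies within the scatter) and an at least 1.5-fold lower number from compound 2 to compound 3 (0.18 log units; that floor lies within the scatter) can be read only as floors, and a step that the two limits leave unreadable from compound 1 to compound 2 cannot be read at all. Compound 4 `CCc1cccc2c(OC)c(-c3occ(C)c3COC(=O)CCN(CC)CC)ccc12` differs from compound 3 by (2-(diethylamino)ethyl)carbonyl in place of 2,2,2-trifluoroethyl on an oxygen on a saturated carbon. For the measured compounds named here, no measured step touches a change of this kind, and the two steps that end at compound 3 carry only floors that lie within the scatter. The step from compound 3 to compound 4 is therefore expected to be a 1.2-fold higher number from compound 3 to compound 4 (0.08 log units; within the scatter), nothing beyond the scatter. The estimate for compound 4 is 8 ug/mL, with a range from 3 ug/mL to 25 ug/mL.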

Compound 4, concentration for half-maximal effect: > 10 ug/mL
Compound 4 was reported as a limit; the forecaster's own chance of this, stated with the estimate: 40%; middle value at least 1.2-fold (0.09 log units) away from the limit.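

In this assay compound 4 gives > 10 ug/mL, which is a limit of the assay and not a number. Placing (2-(diethylamino)ethyl)carbonyl on this oxygen in place of 2,2,2-trifluoroethyl gives an at least 1.5-fold higher number from compound 3 to compound 4 (0.18 log units; that floor lies within the scatter), so the change can be read only as a floor, and its true size stays unknown. The steps to compound 4 from compound 1 and compound 2 cannot be read, and compound 3 remains the only one of the series with a real number, while a larger group containing nitrogen now ends at the same limit as the ethoxy and bromo compounds: the limit of > 10 ug/mL in this assay, at which 3 of the 4 values shown sit.

The entering group brings in a carbonyl and a nitrogen together, so these compounds cannot separate the two. From the compounds shown here alone, it also stays open whether a plain amine or a carboxylic acid at this saturated carbon would give a real number.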